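A pyridin-2-yl swap on a compound at the limit

The source may hold more compounds than are shown below. What is called first, only, known or untested is meant among the compounds shown, and "the series" means these compounds.

Measured in a functional assay on HOS-TE85 cells (Homo sapiens) for inhibition, read by CCK-8 assay, with a stated time of 72 h; on this read-out higher numbers stand for weaker inhibition and lower numbers for stronger inhibition:
Compound 1 `COc1ccc(F)cc1N1C(=O)CSC1c1cccc(C(=O)NCCCCn2cccn2)c1`: 97.3 nM
Compound 2 `O=C(NCCCCn1cccn1)c1cccc(C2SCC(=O)N2c2cccnc2)c1`: > 1000 nM

Compound 2 has no number, only a limit: it stands at the limit of > 1000 nM in this assay, at which 1 of the 2 values shown sits. Compound 3 `O=C(NCCCCn1cccn1)c1cccc(C2SCC(=O)N2c2ccccn2)c1` differs from it in one place: pyridin-2-yl in place of pyridin-3-yl on an amide-type nitrogen in a ring. Among the compounds with values here, one measured step bears on this: an at least 10-fold higher number from compound 1 to compound 2 (1.01 log units; beyond the scatter), a large step on that same nitrogen, though none measured exchanges one pyridinyl for another. The expected outcome is no clear gain, with a step that the limit leaves unreadable from compound 2 to compound 3 in this assay. For compound 3 the estimated value is 1500 nM, with an expected range of 400 nM to 5000 nM.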

Compound 3, half-maximal inhibitory concentration: 60.3 nM
Estimate against measurement, compound 3: 25-fold (1.40 log units) above; the measured number lies below the stated range.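

The two pyridinyl groups hold the same atoms joined differently, yet in this assay this exchange on the amide-type nitrogen gives an at least 16-fold lower number from compound 2 to compound 3 (1.21 log units; beyond the scatter). Compound 2 stands at a limit, not at a number: the limit of > 1000 nM in this assay, at which 1 of the 3 values shown sits. The earlier drop on this nitrogen therefore does not hold for every pyridinyl group, since pyridin-2-yl in place of 5-fluoro-2-methoxyphenyl gives a 1.6-fold lower number from compound 1 to compound 3 (0.21 log units; within the scatter).

The compounds shown leave open how pyridin-4-yl, or a pyridin-2-yl carrying a methoxy group or a fluorine, would read in this assay.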